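Difluorophenyl in Place of Methoxyphenyl on the Carbinol Ether

A few compounds are considered here, and "the series" means these few. Any claim that something is new, unique, unknown or untested is made for them only; others in the source may bear on it.

In an assay on isolated protein for activation of cGMP-dependent protein kinase 1 (Homo sapiens), read by ADP-Glo, with stated times of 30 min and 2 h, in the presence of a further agent that is not named here (on this read-out higher numbers stand for an effect only at larger amounts of compound and lower numbers for an effect already at smaller amounts), compound 1 `COc1cccc([C@@H](CO)O[C@H]2CCCN(Cc3ccc(C(=O)O)cc3C)[C@H]2c2ccccc2)c1` gives 81000 nM. Compound 3 `Cc1cc(C(=O)O)ccc1CN1CC[C@H](OC(CO)c2cc(Cl)cc(Cl)c2)[C@@H]1c1ccccc1` gives 133000 nM in this assay, a number within the scatter of compound 1. Compound 2 `O=C(O)C12CC(CN3CCC[C@H](O[C@H](CO)c4cc(Cl)cc(Cl)c4)[C@@H]3c3ccccc3)(C1)C2` gives 12000 nM, a lower number than compound 1 and beyond the scatter; compound 2 differs from compound 1 in more than one place, so no single step can be read from it. Compound 4 `Cc1cc(C(=O)O)ccc1CN1CCC[C@H](O[C@H](CO)c2cc(F)cc(F)c2)[C@@H]1c1ccccc1` is compound 1 with 3,5-difluorophenyl in place of 3-methoxyphenyl on a saturated chain carbon bound to an oxygen on a saturated carbon and a saturated chain carbon. Among the compounds with values here, the only measured compounds carrying a dihalogenated ring are compound 2 with 12000 nM and compound 3 with 133000 nM, each on a different core. In this assay the expected step is a 2.0-fold lower number from compound 1 to compound 4 (0.31 log units; beyond the scatter), a modest lowering. Compound 4 is estimated at 40000 nM, with a range of 10000 nM to 150000 nM.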

Compound 4, half-maximal effective concentration: 1500 nM
For compound 4 the middle estimate is 27-fold (1.43 log units) above the measured one, and the stated range ends above it.
By their numbers in this assay, from the lowest: compound 4; then compound 2; then compounds 1 and 3 (each within the scatter of the next).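

In this assay, the aryl group on the carbinol ether proves to be a sensitive point in the series: 3,5-difluorophenyl in place of 3-methoxyphenyl gives a 54-fold lower number from compound 1 to compound 4 (1.73 log units; beyond the scatter). Within the data shown here, the earlier compounds offered no step that changed one place, so this is the first direct reading at this position. No measurement shown accounts for the size of this step. On these data alone, it remains open whether a single fluorine on this ring would retain the lower number. Also open, as far as these compounds go, is how a nitrile on this ring would compare.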